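Thiophen-3-yl to thiophen-2-yl on compound 1

The source may report more compounds than this note shows. Statements on the series, on what has been measured and on what is new or still open speak of the compounds shown alone.

Measured in a functional assay on MCF7 cells (Homo sapiens) for antiproliferative activity, read by MTT assay; a higher number here means a weaker inhibitor, a lower number a stronger inhibitor:
Compound 1 `COc1ccc([C@@H]2[C@@H](c3ccsc3)C(=O)N2c2cc(OC)c(OC)c(OC)c2)cc1O`: 10 nM
Compound 2 `COc1ccc([C@@H]2C(C3CCCCC3)C(=O)N2c2cc(OC)c(OC)c(OC)c2)cc1`: 580 nM

Of these two, compound 1 has the lower number, which makes it the stronger inhibitor, and its gap to compound 2 lies well beyond the usual scatter of repeated measurements.

The next compound to be tested is compound 3 `COc1ccc([C@@H]2[C@@H](c3cccs3)C(=O)N2c2cc(OC)c(OC)c(OC)c2)cc1O`, which has the same atoms as compound 1, joined differently. Thiophen-2-yl replaces thiophen-3-yl on a saturated ring carbon (thiophen-2-yl in place of thiophen-3-yl on a saturated ring carbon). The rest of the molecule stays as it is in compound 1.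

Within the data shown here, no pair of measured compounds isolates a change of this kind, so the data give no direct guide to its size. The entering and leaving groups are close relatives, which argues against a large shift. Among the measured compounds shown here, with compound 1 at 10 nM, the lower of the two numbers so far, a small drift upward seems a little likelier than one downward. The estimated step of a 1.4-fold higher number from compound 1 to compound 3 (0.15 log units; within the scatter) is expected to stay within the usual scatter. For compound 3 the estimate is 14 nM, with an expected range from 5 nM to 45 nM.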

Compound 3, half-maximal inhibitory concentration: 7 nM
Beside the measured number, compound 3's estimate is 2.0-fold (0.30 log units) above it, within the range that was stated.
By their numbers in this assay, from the lowest: compounds 3 and 1 (each within the scatter of the next); then compound 2.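

In this assay, thiophen-2-yl in place of thiophen-3-yl on a saturated ring carbon gives a 1.4-fold lower number from compound 1 to compound 3 (0.15 log units; within the scatter), so compound 1 and compound 3 cannot be told apart. Among these compounds, this is the first direct reading at this position, and it shows that the same five-membered aromatic ring, attached through a different ring atom, leaves the number within the usual scatter of repeated measurements. Nothing measured here explains why the two attachments read alike.

The compounds shown leave open how far this tolerance extends, for instance to a phenyl ring, a furan-2-yl group or an aminomethyl group on the same saturated ring carbon of the four-membered ring. Compound 2 carries a cyclohexyl group at this carbon, but it differs from compound 1 in more than one place, so it cannot show what the cyclohexyl group alone does to the number.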